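The compounds below may be only part of what the source reports. "The series", "measured", "known", "first", "only" and "open" are said of these compounds alone.

Three compounds share one core in a functional assay on HCT-15 cells (Homo sapiens) for cytotoxicity, read by sulforhodamine B assay, with a stated time of 48 h; a lower number here means that less compound is tolerated, a higher number that more compound is tolerated. Compound 1 `ClCc1cccc(Cn2cnc3c(Cl)ncnc32)c1` gives 10000 nM in this assay. Compound 3 `ClCc1ccccc1Cn1cnc2ncnc(Cl)c21`, which carries its chloromethyl group elsewhere on the benzyl ring, gives 6160 nM in this assay. Compound 2 `ClCc1cccc(Cn2cnc3c(Cl)nc(Cl)nc32)c1` gives only a limit, > 100000 nM, in this assay, so only a limit is known for it. Within the data shown here, the step of an at least 10-fold higher number from compound 1 to compound 2 (1.00 log units; beyond the scatter) is the one measured change here, and its size rests on (the limit of > 100000 nM in this assay, at which 1 of the 3 values shown sits), at which compound 2 sits.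

Compound 4 `Nc1nc(Cl)c2ncn(Cc3cccc(CCl)c3)c2n1` differs from compound 2 in one place: amino in place of chloro on an aromatic carbon. The change touches the same carbon that took the chloro group in the step from compound 1 to compound 2; there, adding chloro raised the number in this assay beyond the scatter, as an at least 10-fold higher number from compound 1 to compound 2 (1.00 log units; beyond the scatter) shows. Whether an amino group at this carbon behaves like hydrogen or like chloro is not told by these three compounds. Taking the removal of the chloro as the guiding fact, compound 4 is expected to give 30000 nM in this assay, between 5000 nM and 150000 nM. That estimate means a step of an at least 3.3-fold lower number from compound 2 to compound 4 (0.52 log units; beyond the scatter) toward a lower number, though a limit remains possible.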

Compound 4, concentration lethal to 50% of the cells: 33100 nM
Compound 4: the middle estimate sits 1.1-fold (0.04 log units) below what was measured, and the stated range covers the measured number.
By their numbers in this assay, from the lowest: compounds 3 and 1 (each within the scatter of the next); then compound 4. At a limit, above all of these: compound 2.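

At the carbon between two ring nitrogen atoms, amino proves to be neither equivalent to hydrogen nor equivalent to chloro in this assay. Against hydrogen, the replacement gives a 3.3-fold higher number from compound 1 to compound 4 (0.52 log units; beyond the scatter), and against chloro it gives an at least 3.0-fold lower number from compound 2 to compound 4 (0.48 log units; beyond the scatter), so both steps lie beyond the scatter and the amino compound falls in the middle of this small series, with hydrogen lowest and chloro at a limit on the high side. The first of these steps has a measured number at both ends, but the distance from amino to chloro stays open-ended, since compound 2 holds only a limit: the limit of > 100000 nM in this assay, at which 1 of the 4 values shown sits.

The compounds shown do not tell where a methylamino group, a dimethylamino group, a methoxy group or a fluoro group at this carbon would fall relative to hydrogen, amino and chloro. Also open, from the compounds shown here alone, is whether amino at this carbon would give a similar step with the chloromethyl group placed as in compound 3, which gives 6160 nM with hydrogen at that carbon.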